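Esterifying the Phenol of Compound 1 Weakens Cytotoxicity

The source may report more compounds than this note shows. Statements on the series, on what has been measured and on what is new or still open speak of the compounds shown alone.

Measured compounds:
compound 1 `COC(=O)/C(=C\c1ccc(O)cc1)Sc1ccnc2cc(Cl)ccc12`: 4310 nM
compound 2 `COC(=O)/C(=C\c1ccc(OC(=O)c2cccc(OC)c2)cc1)Sc1ccnc2cc(Cl)ccc12`: 25500 nM
compound 3 `COC(=O)/C(=C\c1ccc(OC(=O)c2c(OC)cccc2OC)cc1)Sc1ccnc2cc(Cl)ccc12`: 37200 nM

In a functional assay on HL-60 cells (Homo sapiens) for cytotoxicity, read by MTT assay, with a stated time of 24 h (a higher number here means a weaker inhibitor, a lower number a stronger inhibitor), compound 1 gives 4310 nM, the lowest number of the three measured compounds. Compound 2 and compound 3, which carry an ester on the phenol oxygen of the shared core, both sit higher: a 5.9-fold higher number from compound 1 to compound 2 (0.77 log units; beyond the scatter) and an 8.6-fold higher number from compound 1 to compound 3 (0.94 log units; beyond the scatter). Between the two esters the gap is small, a 1.5-fold higher number from compound 2 to compound 3 (0.16 log units; within the scatter), so the pattern of methoxy groups on the benzoyl ring made little difference in this assay.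

Compound 4 `COC(=O)/C(=C\c1ccc(OC(=O)c2cccc(OC)c2OC)cc1)Sc1ccnc2cc(Cl)ccc12` is not yet measured. It differs from compound 1 in one place: (2,3-dimethoxyphenyl)carbonyl in place of hydrogen on an oxygen on an aromatic ring. The two measured steps from compound 1 to an ester both bear on this change, and both were modest and in the same direction, towards weaker inhibition. The expectation is therefore a step of similar size: a 7.0-fold higher number from compound 1 to compound 4 (0.84 log units; beyond the scatter). For compound 4 the estimated value in this assay is 30000 nM, with a likely range from 12000 nM to 70000 nM.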

Compound 4, half-maximal inhibitory concentration: 13000 nM
Estimate against measurement, compound 4: 2.3-fold (0.36 log units) above, within the range that was stated.
By their numbers in this assay, from the lowest: compound 1; then compounds 4, 2 and 3 (each within the scatter of the next, the first and the last beyond it).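

All three esters on this oxygen give higher numbers than the free phenol, and the 2,3-dimethoxyphenyl ester does so with a 3.0-fold higher number from compound 1 to compound 4 (0.48 log units; beyond the scatter). The arrangement of the methoxy groups can matter after all: swapping 2,6-dimethoxyphenyl for 2,3-dimethoxyphenyl on the carbonyl carbon gives a 2.9-fold lower number from compound 3 to compound 4 (0.46 log units; beyond the scatter), a change beyond the scatter that the earlier pair of esters did not reveal. Adding one methoxy to the ring of compound 2 gives a 2.0-fold lower number from compound 2 to compound 4 (0.29 log units; within the scatter), which stays within the scatter, so that addition alone shows no clear effect.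

Nothing available here explains why the two dimethoxyphenyl esters differ. On these data alone, it also remains open how a plain benzoyl ester with no methoxy groups, or a methyl ether or a carbamate on the same oxygen, would compare with the free phenol of compound 1.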